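The compounds below may be only part of what the source reports. "The series", "measured", "known", "first", "only" and "open" are said of these compounds alone.

Of the compounds shown here, two have been measured in an assay on isolated protein for inhibition of malate dehydrogenase, mitochondrial (Sus scrofa); on this read-out higher numbers stand for weaker inhibition and lower numbers for stronger inhibition. Compound 1 `N#Cc1cc(CCOc2cc(O)c3c(=O)cc(C(=O)O)oc3c2)ccc1NC(=O)C(=O)O` gives 17100 nM. Compound 2 `COc1ccc(CNC(=O)c2cc(=O)c3c(O)cc(OCCc4ccc(NC(=O)C(=O)O)cc4)cc3o2)cc1` gives 2720 nM and so holds the lowest number of the two, with compound 1 the nearest neighbour. Compound 1 and compound 2 differ in more than one place, so their values show only what each compound does on its own. Compound 3 `COc1ccc(CNC(=O)c2cc(=O)c3c(O)cc(OCCc4ccc(NC(=O)C(=O)O)c(C#N)c4)cc3o2)cc1` is not yet measured; it differs from compound 2 by cyano in place of hydrogen on an aromatic carbon. No comparable single change has been measured, so a step no larger than the scatter is expected, in either direction. For compound 3 the estimated value in this assay is 3200 nM, with a range from 1200 nM to 8500 nM, meaning an expected step of a 1.2-fold higher number from compound 2 to compound 3 (0.07 log units; within the scatter).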

Compound 3, half-maximal inhibitory concentration: 5910 nM
Compound 3: middle estimate off by 1.8-fold (0.27 log units), on the low side; measured number inside the range.
By their numbers in this assay, from the lowest: compound 2; then compound 3; then compound 1.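

In this assay, cyano in place of hydrogen, ortho to a (carboxycarbonyl)amino group, weakens inhibition, with a 2.2-fold higher number from compound 2 to compound 3 (0.34 log units; beyond the scatter) in the series bearing the (4-methoxybenzyl)amino group. With cyano kept, the change at the carbonyl carbon runs the other way, with a 2.9-fold lower number from compound 1 to compound 3 (0.46 log units; beyond the scatter) on (4-methoxybenzyl)amino in place of hydroxy. No measurement here gives a reason for either step.

As far as these compounds go, whether chloro or methoxy at this position would give a similar step remains open. So does whether a benzylamino group without the methoxy keeps the gain at the carbonyl carbon.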